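From a methylphenyl amide to a difluorophenyl amide

The source may report more compounds than this note shows. Statements on the series, on what has been measured and on what is new or still open speak of the compounds shown alone.

Compound 1 `Cc1ccc(C(=O)Nc2cccc(-c3oc4cc(-c5ccc(F)cc5)ccc4c(=O)c3O)c2)cc1` is the reference of this small set. In a functional assay on HeLa cells (Homo sapiens) for antiproliferative activity, read by CCK-8 assay, with a stated time of 72 h (a higher number here means a weaker inhibitor, a lower number a stronger inhibitor), compound 1 gives 6190 nM, the lowest of the three numbers recorded. Compound 2 `COc1ccccc1C(=O)Nc1cccc(-c2oc3cc(-c4ccc(F)cc4)ccc3c(=O)c2O)c1` gives 14100 nM in this assay, and compound 3 `Cc1ccccc1C(=O)Nc1cccc(-c2oc3cc(-c4ccc(F)cc4)ccc3c(=O)c2O)c1` gives 11900 nM. The measured steps are a 2.3-fold higher number from compound 1 to compound 2 (0.36 log units; beyond the scatter), a 1.9-fold higher number from compound 1 to compound 3 (0.28 log units; within the scatter) and a 1.2-fold lower number from compound 2 to compound 3 (0.07 log units; within the scatter).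

Compound 4 `O=C(Nc1cccc(-c2oc3cc(-c4ccc(F)cc4)ccc3c(=O)c2O)c1)c1cc(F)cc(F)c1` has not yet been measured. Its difference from compound 1 is 3,5-difluorophenyl in place of 4-methylphenyl on a carbonyl carbon. The two steps that bear on it are those that also exchange the aryl group on the carbonyl carbon, namely a 2.3-fold higher number from compound 1 to compound 2 (0.36 log units; beyond the scatter) and a 1.9-fold higher number from compound 1 to compound 3 (0.28 log units; within the scatter); both moved the number up, once modestly and once within the scatter. Among the measured compounds shown here, no measured step introduces fluorine on this aryl group, so the direction of any fluorine effect is unknown. Compound 4 is therefore expected to sit near compound 1 in this assay, at about 7000 nM, within a range from 3000 nM to 16000 nM. This estimate means a step of a 1.1-fold higher number from compound 1 to compound 4 (0.05 log units; within the scatter), expected to remain within the scatter.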

Compound 4, half-maximal inhibitory concentration: 3380 nM
Compound 4: the middle estimate sits 2.1-fold (0.32 log units) above what was measured; measured number inside the range.
By their numbers in this assay, from the lowest: compounds 4, 1, 3 and 2 (each within the scatter of the next, the first and the last beyond it).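

Among the compounds shown here, compound 4 is the only compound here with fluorine on the aryl group at the carbonyl carbon, and a 1.8-fold lower number from compound 1 to compound 4 (0.26 log units; within the scatter) shows that in this assay 3,5-difluorophenyl can replace 4-methylphenyl at this position with no change beyond the scatter. For the compounds shown here, the exchanges for the other two aryl groups give a 3.5-fold lower number from compound 3 to compound 4 (0.55 log units; beyond the scatter) and a 4.2-fold lower number from compound 2 to compound 4 (0.62 log units; beyond the scatter) and so widen the spread at this position beyond any step among the earlier compounds. Nothing available explains why these aryl groups differ.

It remains open whether both fluorines are needed, since a phenyl group with a single fluorine does not appear among these compounds. Going by these compounds, it is also open how a trifluoromethyl group, an amine or a carboxylic acid on this aryl ring would behave in this assay when set against the 3,5-difluorophenyl amide.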